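Chain-terminal hydroxy to fluoro on the shared core

A few compounds are considered here, and "the series" means these few. Any claim that something is new, unique, unknown or untested is made for them only; others in the source may bear on it.

Among the compounds with values here, compound 1 `CC(=O)OCCc1c(C)nc(Cl)nc1Cl` and compound 2 `COc1nc(Cl)nc(C)c1CCO` are the two measured members of the set. In a functional assay on HCT-116 cells (Homo sapiens) for antiproliferative activity, read by MTT assay, with a stated time of 24 h (on this read-out higher numbers stand for weaker inhibition and lower numbers for stronger inhibition), compound 1 gives > 100000 nM, which is a limit of the assay and not a number. In this assay compound 2 likewise gives > 100000 nM, again a limit rather than a measured number. Within the data shown here, compound 2 therefore stands at the limit of > 100000 nM in this assay, at which 2 of the 2 values shown sit, and no measured step is available to set against the change that follows. Compound 3 `COc1nc(Cl)nc(C)c1CCF` differs from compound 2 by fluoro in place of hydroxy on a saturated chain carbon, two bonds along the chain from an aromatic carbon. Among the measured compounds shown here, no step between measured compounds bears on this exchange. Expected is a number no higher from compound 2 to compound 3 (the limit leaves the size open) in this assay, no shift beyond the scatter, since both measured values sit at the limit of > 100000 nM in this assay, at which 2 of the 2 values shown sit. Compound 3 is expected to give 100000 nM, within 30000 nM to 300000 nM, most probably reported as a further limit.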

Compound 3, half-maximal inhibitory concentration: > 100000 nM
Compound 3 gave a limit, no number (the forecaster's own chance of this, stated with the estimate: 85%); the middle value sits exactly at the limit.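

In this assay compound 3 gives > 100000 nM, a limit and not a number, and the exchange of hydroxy for fluoro between compound 2 and compound 3 cannot be read as a step. The compounds shown leave open which change on the shared core, if any, would give a measurable number in this assay.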